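This account rests on a few compounds, and the source may have more. Where it says the series, first, only, none or still open, it means among the compounds named here.

Measured so far in a functional assay on PC-3 cells (Homo sapiens) for inhibition, read by colorimetric assay and MTT assay, with a stated time of 72 h; on this read-out higher numbers stand for weaker inhibition and lower numbers for stronger inhibition
- compound 1 `Cn1c2cnc1OCCCCCCCCCCOc1ccccc1-2` gives 31000 nM
- compound 2 `CCCCOc1ncc(-c2ccccc2OC)n1C` gives 71000 nM
- compound 3 `C=CCCCCOc1ncc(-c2cc(F)c(F)cc2OC)n1C` gives 40000 nM

Compound 2 holds the highest of the three numbers. Its gap to compound 3 lies within the scatter, and its gap to compound 1 lies beyond it.

The step under consideration leads to compound 4 `COc1ccccc1-c1cnc(OCCCc2ccccc2)n1C`, which is not yet measured. The change from compound 2 is counted as phenyl in place of methyl on a saturated chain carbon, three bonds along the chain from an oxygen on an aromatic ring and reads in words as phenyl in place of methyl on a saturated chain carbon, three bonds along the chain from an oxygen on an aromatic ring.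

Among the compounds with values here, no measured pair isolates this change. The expectation therefore rests only on the narrow range of the series, with compound 1 at 31000 nM and compound 3 at 40000 nM marking the rest of it. In this assay the expected step is a 1.8-fold lower number from compound 2 to compound 4 (0.25 log units; within the scatter) as a small move toward a lower number, within the scatter. For compound 4 the estimated value is 40000 nM with an expected range from 15000 nM to 80000 nM as its limits.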

Compound 4, half-maximal inhibitory concentration: 27000 nM
For compound 4 the middle estimate is 1.5-fold (0.17 log units) above the measured one, and the stated range covers the measured number.
By their numbers in this assay, from the lowest: compounds 4, 1, 3 and 2 (each within the scatter of the next, the first and the last beyond it).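

In this assay, within the data shown here, the change gives a 2.6-fold lower number from compound 2 to compound 4 (0.42 log units; beyond the scatter), the first step that isolates a single place. Phenyl in place of methyl on a saturated chain carbon, three bonds along the chain from an oxygen on an aromatic ring, is therefore accepted at this position, and the modest step lies beyond the scatter. Nothing measured here accounts for the step.

Among these compounds, the single pair cannot separate a contribution of the aromatic ring from that of the added heavy atoms, and a cyclohexyl group at the same place would address this. Also open, from the compounds shown here alone, are how a longer chain ending in phenyl or an amine on the phenyl would move the number.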